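This account rests on a few compounds, and the source may have more. Where it says the series, first, only, none or still open, it means among the compounds named here.

Measured compounds:
- compound 1, `CC(C)C(=O)Nc1cccc(C2CCN(Cc3cccc(Oc4cccc(C(F)(F)F)c4)c3)CC2)c1`: in an assay on isolated protein for displacement of a labelled ligand from melanin-concentrating hormone receptor 1 (Rattus norvegicus) (a higher number here means a weaker inhibitor, a lower number a stronger inhibitor), compound 1 gives 65 nM
- compound 2, `CC(C)C(=O)Nc1cccc(C2CCN(Cc3cccc(Oc4ccc(Cl)c(Cl)c4)c3)CC2)c1`: in this assay compound 2 gives 18 nM

Among the measured compounds shown here, compound 2 stands at the lower of the two numbers in this assay; its only neighbour is compound 1, and the step of a 3.6-fold lower number from compound 1 to compound 2 (0.56 log units; beyond the scatter) came with the change 3,4-dichlorophenyl in place of 3-(trifluoromethyl)phenyl on an oxygen on an aromatic ring.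

Compound 3, `CC(C)C(=O)Nc1cccc(C2CCN(Cc3cccc(Oc4cc(Cl)cc(Cl)c4)c3)CC2)c1`, has not yet been measured. It differs from compound 2 in one place: 3,5-dichlorophenyl in place of 3,4-dichlorophenyl on an oxygen on an aromatic ring. The two compounds hold the same atoms, joined differently, so the change is only in where the two chlorines sit on that ring.

For the measured compounds named here, no measured step speaks to this exact change; the one step that exists, from compound 1 to compound 2, swapped the whole ring substituent rather than moving chlorines on it. With nothing that points in either direction, compound 3 is expected to land close to compound 2, and the step of a 1.4-fold higher number from compound 2 to compound 3 (0.14 log units; within the scatter) is estimated to stay within the scatter. The estimated value for compound 3 in this assay is 25 nM, with a range from 8 nM to 80 nM.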

Compound 3, inhibition constant: 140 nM
For compound 3 the middle estimate is 5.6-fold (0.75 log units) below the measured one; measured number outside the range, above it.
By their numbers in this assay, from the lowest: compound 2; then compound 1; then compound 3.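

Moving the two chlorines changes no atom and none of the counts for the ring, yet in this assay the result is a 7.8-fold higher number from compound 2 to compound 3 (0.89 log units; beyond the scatter), so on this ring the placement of the chlorines matters, not just their presence. The second new step, a 2.2-fold higher number from compound 1 to compound 3 (0.33 log units; beyond the scatter), shows that a dichlorophenyl group does not as such give a lower number than 3-(trifluoromethyl)phenyl: compound 2 lies below compound 1 and compound 3 lies above it, so the order of these two kinds of ring depends on which dichlorophenyl group is compared. Nothing available here explains why the placement of the chlorines makes this difference.

The compounds shown leave open how much each chlorine contributes, since none has a ring with a single chlorine or an unsubstituted phenyl ring. They also leave open whether the same sensitivity to placement would hold for other groups on this ring, such as fluorine, methyl or methoxy, or for the same chlorine patterns on a different core.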